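The compounds below may be only part of what the source reports. "The series", "measured", "known", "first", "only" and "open" are said of these compounds alone.

Of the compounds shown here, three of a shared core have been measured in an assay on MDA-MB-231 cells for binding affinity to C-X-C chemokine receptor type 4 (Homo sapiens), read by immunofluorescence and microscopy, with stated times of 10 min and 30 min; a lower number here means that less compound is needed, a higher number that more compound is needed for the effect. Compound 1 `Cc1ccc(S(=O)(=O)NCc2ccc(CNC(=O)c3ccc([N+](=O)[O-])cc3)cc2)cc1` gives 10 nM. Compound 2 `O=C(NCc1ccc(CNS(=O)(=O)c2ccccc2)cc1)c1ccc([N+](=O)[O-])cc1` gives 100 nM, and compound 3 `COc1ccccc1C(=O)NCc1ccc(CNS(=O)(=O)c2ccc(C)cc2)cc1` gives 100 nM. Compound 2 thus stands level with compound 3 at the digits shown, the two together giving the highest numbers of the three, while compound 1 is the furthest from compound 2: the step of a 10-fold higher number from compound 1 to compound 2 (1.00 log units; beyond the scatter) is a modest change coming from a hydrogen in place of a methyl on an aromatic carbon.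

The next compound, compound 4 `O=C(NCc1ccc(CNS(=O)(=O)c2ccccc2)cc1)c1ccc(Cl)cc1`, differs from compound 2 by chloro in place of nitro on an aromatic carbon.

Within the data shown here, no measured step swaps chloro for nitro, so the closest guide is the step of a 10-fold higher number from compound 1 to compound 3 (1.00 log units; beyond the scatter), where a 2-methoxyphenyl took the place of the 4-nitrophenyl on the carbonyl carbon. That shows that altering this aryl group at all can move the number by a modest amount, though it gives no direct reading for a chloro. The step of a 10-fold higher number from compound 1 to compound 2 (1.00 log units; beyond the scatter) lies at the other end of the shared core and bears on the change only by showing the scale of moves this series allows.

A modest rise in the number, a 2.5-fold higher number from compound 2 to compound 4 (0.40 log units; beyond the scatter), is therefore expected, with some chance of no change beyond the scatter. The estimate for compound 4 in this assay is 250 nM, between 80 nM and 800 nM.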

Compound 4, effective concentration (reported as EC, without a stated level of effect): 100 nM
The estimate for compound 4 lay 2.5-fold (0.40 log units) above the measured number, and the stated range covers the measured number.
By their numbers in this assay, from the lowest: compound 1; then compounds 2, 3 and 4 (each within the scatter of the next).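

Putting chloro in place of nitro on this aromatic carbon, para to a large group, gives no change at the digits printed from compound 2 to compound 4 (within the scatter) in this assay, so the number does not depend on the nitro group here, at least in the series without the methyl. The earlier step at this end of the molecule, a 10-fold higher number from compound 1 to compound 3 (1.00 log units; beyond the scatter), replaced the whole 4-nitrophenyl with a 2-methoxyphenyl, changing both the group and where it sits, whereas the new step changes only the group on one carbon and shows that a swap of 3 heavy atoms for 1 can leave the number where it was. No measurement at hand explains why these two groups read alike.

On these data alone, it remains open whether chloro would also match nitro alongside the methyl that separates compound 1 from compound 2, since the two steps at this end of the molecule were read on different partners. With only nitro and chloro shown on this carbon, it is also open how an amine, a carboxylic acid or a longer chain there would read in this assay.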